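The source may hold more compounds than are shown below. What is called first, only, known or untested is meant among the compounds shown, and "the series" means these compounds.

Compound 1 `CC(=O)OCC(=O)OCCc1c(-c2ccccc2Cl)c2cc(Cl)ccc2[nH]c1=O`: 100000 nM
Compound 2 `CC12CCC(C(=O)OCCc3c(-c4ccccc4Cl)c4cc(Cl)ccc4[nH]c3=O)(OC1=O)C2(C)C`: > 1800000 nM (a limit)
Compound 3 `O=C(OCCc1c(-c2ccccc2Cl)c2cc(Cl)ccc2[nH]c1=O)c1ccc([N+](=O)[O-])cc1`: 1600000 nM

These compounds were tested in an ADME assay on HepG2 2.2.15 cells (Homo sapiens) for cytotoxicity (a higher number here means that more compound is tolerated, a lower number that less compound is tolerated), and they differ only in the group on a carbonyl carbon. Of the two exact numbers, the higher belongs to compound 3 at 1600000 nM, and compound 1 is well beneath it. Compound 2 gives > 1800000 nM, which is a limit and not a number.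

The next compound is compound 4 `O=C(COc1ccccc1)OCCc1c(-c2ccccc2Cl)c2cc(Cl)ccc2[nH]c1=O`, not yet measured. The change is phenoxymethyl in place of 4-nitrophenyl on a carbonyl carbon.

Among the compounds with values here, three measured steps bear on this. Replacing the acetoxymethyl of compound 1 gave two large rises: an at least 18-fold higher number from compound 1 to compound 2 (1.25 log units; beyond the scatter) and a 16-fold higher number from compound 1 to compound 3 (1.20 log units; beyond the scatter). The remaining step, an at least 1.1-fold lower number from compound 2 to compound 3 (0.05 log units; that floor lies within the scatter), stays within the scatter at its floor. The new group keeps an aromatic ring like the group of compound 3. It also ends in an oxymethyl link like the group of compound 1. Compound 4 is therefore expected to fall between compound 1 and compound 3, probably nearer compound 3.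

The expected change is modest and downward, estimated as a 2.7-fold lower number from compound 3 to compound 4 (0.43 log units; beyond the scatter). For compound 4 the estimated value is 600000 nM, with an expected range of 150000 nM to 1800000 nM.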

Compound 4, half-maximal cytotoxic concentration: 81000 nM
For compound 4 the middle estimate is 7.4-fold (0.87 log units) above the measured one; the measured number lies below the stated range.
By their numbers in this assay, from the lowest: compounds 4 and 1 (each within the scatter of the next); then compound 3. At a limit, above all of these: compound 2.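

Keeping a six-membered aromatic ring on the carbonyl carbon was not enough to hold the number up in this assay: replacing 4-nitrophenyl with phenoxymethyl gave a 20-fold lower number from compound 3 to compound 4 (1.30 log units; beyond the scatter), and the comparison with the third group gave an at least 22-fold lower number from compound 2 to compound 4 (1.34 log units; beyond the scatter). Compound 4 instead sits level with compound 1, with a 1.2-fold lower number from compound 1 to compound 4 (0.09 log units; within the scatter), so phenyl in place of acetyl on an oxygen on a saturated carbon makes no difference that can be told apart here, and among these four compounds the two low numbers belong to the acetoxymethyl and phenoxymethyl groups, with no compound going against that grouping. Compound 2 gives a limit of the assay and not a number, so its true distance from the others stays unfixed: the limit of > 1800000 nM in this assay, at which 1 of the 4 values shown sits.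

The compounds shown cannot separate the role of the oxygen in the link from that of the extra carbon, which a plain benzyl group or a longer carbon chain on the same carbonyl carbon could help to test. Nor can they say whether the nitro group of compound 3 matters, a question that an unsubstituted phenyl or a 4-aminophenyl group would address.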